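Ring nitrogen substituent changes in a weakly binding series

The source may report more compounds than this note shows. Statements on the series, on what has been measured and on what is new or still open speak of the compounds shown alone.

Compound 1 `CC(C)(N)C(=O)N[C@H](COCc1ccccc1)c1nnn(Cc2ccccc2)n1` is the reference point of the series. In an assay on isolated protein for displacement of a labelled ligand from growth hormone secretagogue receptor type 1 (Homo sapiens), with a stated time of 1 h (on this read-out lower numbers stand for stronger inhibition and higher numbers for weaker inhibition), compound 1 gives 4750 nM. Compound 2 `CC(C)(N)C(=O)N[C@H](COCc1ccccc1)c1nnn(Cc2cccc(NS(C)(=O)=O)c2)n1` carries methanesulfonamido in place of hydrogen on an aromatic carbon. In this assay compound 2 reaches only the limit of the measurement, > 5000 nM. Compound 3 `COC(=O)C(c1ccccc1)n1nnc([C@@H](COCc2ccccc2)NC(=O)C(C)(C)N)n1` carries methoxycarbonyl in place of hydrogen on a saturated chain carbon bound to an aromatic carbon and an aromatic nitrogen. In this assay compound 3 likewise reaches only the limit, > 5000 nM. Compound 3 therefore stands at the limit of > 5000 nM in this assay, at which 2 of the 3 values shown sit, and has no number of its own; the step of an at least 1.0-fold higher number from compound 1 to compound 3 (0.02 log units; that floor lies within the scatter) and the step of an at least 1.0-fold higher number from compound 1 to compound 2 (0.02 log units; that floor lies within the scatter) both end at that limit.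

Compound 4 `CC(C)(N)C(=O)N[C@H](COCc1ccccc1)c1nnn(CCCCC#N)n1` differs from compound 3 by 4-cyanobutyl in place of methoxycarbonyl)(benzyl on an aromatic nitrogen. Within the data shown here, no measured step touches the 4-cyanobutyl group; the two steps from compound 1, each only a floor within the scatter, show merely that changes around the ring nitrogen have not moved the numbers below the weak starting point. The expectation for compound 4 is accordingly a number no higher from compound 3 to compound 4 (the limit leaves the size open), a number in the same weak region or once more a limit. Compound 4 is estimated at 5000 nM, between 1500 nM and 15000 nM.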

Compound 4, inhibition constant: > 5000 nM
Compound 4 was reported as a limit (the forecaster's own chance of this, stated with the estimate: 50%); the middle value sits exactly at the limit.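

In this assay compound 4 gives > 5000 nM, which is a limit of the assay and not a number. A chain with no ring on this aromatic nitrogen, 3-cyanopropyl in place of the phenyl of the benzyl group, gives an at least 1.0-fold higher number from compound 1 to compound 4 (0.02 log units; that floor lies within the scatter), while the steps to compound 4 from compound 2 and from compound 3 cannot be read. Losing the aromatic ring of the substituent therefore brings no readable improvement on compound 1, and a ringless substituent now ends at the same place as the two ring-bearing ones: the limit of > 5000 nM in this assay, at which 3 of the 4 values shown sit.

Going by these compounds, how far compound 2, compound 3 and compound 4 lie beyond the limit remains unknown, so no order among them can be given. On these data alone, whether an amine or a carboxylic acid at the end of the chain, in place of the nitrile, would give a measurable number remains open.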